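Two inactive sulfonamides and a hydroxyphenyl variant

The compounds below may be only part of what the source reports. "The series", "measured", "known", "first", "only" and "open" are said of these compounds alone.

Compound 1, `Cc1ccc(S(=O)(=O)Nc2ccc3oc(-c4ccccc4)nc3c2)cc1`, in an assay on isolated protein for inhibition of malate dehydrogenase, mitochondrial (Sus scrofa), with stated times of 45 min and 30 min; a lower number here means a stronger inhibitor, a higher number a weaker inhibitor: > 63000 nM
Compound 2, `O=[N+]([O-])c1cc(S(=O)(=O)Nc2ccc(-c3nc4ccccc4o3)cc2)ccc1Cl`, in this assay: > 63000 nM

Both values shown so far are limits of this assay rather than numbers. For compound 1 the value of > 63000 nM is such a limit. For compound 2 the value of > 63000 nM is likewise a limit. Among the measured compounds shown here, compound 1 therefore stands at the edge of what this assay can report, and the limit of > 63000 nM in this assay, at which 2 of the 2 values shown sit, shows that every value recorded here sits at that same limit; no compound has yet given a measurable number.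

Compound 3, `O=S(=O)(Nc1ccc2oc(-c3ccccc3)nc2c1)c1cccc(O)c1`, is the next compound to be measured in this assay. It differs from compound 1 in one place: 3-hydroxyphenyl in place of 4-methylphenyl on a sulfonyl sulfur. For the measured compounds named here, no measured pair shows what such a change does here, so the expectation rests only on where compound 1 stands. Given that compound 1 sits at the limit of this assay, compound 3 is expected to show a step that the limit leaves unreadable from compound 1 to compound 3, no more than the usual scatter. Compound 3 is thus estimated at 80000 nM, within a range from 20000 nM to 320000 nM, with a good chance that only a limit is again reported.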

Compound 3, half-maximal inhibitory concentration: > 63000 nM
Compound 3: a limit, no number; the forecaster's own chance of this, stated with the estimate: 75%; the middle value is on the limit's open side.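

In this assay compound 3 gives > 63000 nM, which is a limit and not a number. No step from compound 1 to compound 3 can be read, because both stand at the same edge: the limit of > 63000 nM in this assay, at which 3 of the 3 values shown sit.

The compounds shown leave open whether 3-hydroxyphenyl in place of 4-methylphenyl changes inhibition at all, and what change would give a measurable number.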